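Shrinking the amide aryl group in an antiproliferative series

This account rests on a few compounds, and the source may have more. Where it says the series, first, only, none or still open, it means among the compounds named here.

In a functional assay on SK-BR-3 cells (Homo sapiens) for antiproliferative activity, read by MTT assay, with a stated time of 72 h (on this read-out higher numbers stand for weaker inhibition and lower numbers for stronger inhibition), compound 2 `CCN1CCN(c2cc(C)c3cc(NC(=O)c4ccc5ccccc5n4)ccc3n2)CC1` gives 3760 nM, the highest of the two numbers shown; compound 1 `CCN1CCN(c2cc(C)c3cc(NC(=O)c4cc5ccccc5[nH]4)ccc3n2)CC1` gives 2550 nM, and the only step measured, a 1.5-fold higher number from compound 1 to compound 2 (0.17 log units; within the scatter), lies within the scatter. Compound 3 `CCN1CCN(c2cc(C)c3cc(NC(=O)c4ccc(OC)cc4)ccc3n2)CC1` carries the change (4-methoxyphenyl in place of quinolin-2-yl on a carbonyl carbon). Within the data shown here, no measured step replaces one aryl group with a smaller one, so none bears directly on this change; the one step recorded swaps two bicyclic groups without a shift beyond the scatter. On this basis the author expects compound 3 to show no step beyond the scatter, a 1.2-fold higher number from compound 2 to compound 3 (0.08 log units; within the scatter), with an estimated value of 4500 nM and a range from 1500 nM to 14000 nM.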

Compound 3, half-maximal inhibitory concentration: 9000 nM
Beside the measured number, compound 3's estimate is 2.0-fold (0.30 log units) below it; low and high end bracket the measured number.
By their numbers in this assay, from the lowest: compounds 1 and 2 (each within the scatter of the next); then compound 3.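

Unlike the swap between the two bicyclic groups, replacing them with the single ring of 4-methoxyphenyl on the carbonyl carbon moves the number beyond the scatter in this assay (a 2.4-fold higher number from compound 2 to compound 3 (0.38 log units; beyond the scatter); a 3.5-fold higher number from compound 1 to compound 3 (0.55 log units; beyond the scatter)). Both steps are modest, but they show that this position is not indifferent to the aryl group it carries. Nothing at hand gives a cause for this shift. The compounds shown leave open whether the loss of the second ring or the methoxy group goes with the higher number. A plain phenyl, or a phenyl carrying an amine or a carboxylic acid, would help separate the two.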